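Swapping the sulfur-linked group of compound 3

The source may hold more compounds than are shown below. What is called first, only, known or untested is meant among the compounds shown, and "the series" means these compounds.

Values in a functional assay on PC-9 cells (Homo sapiens) for antiproliferative activity, read by MTT assay; on this read-out lower numbers stand for stronger inhibition and higher numbers for weaker inhibition:
- Compound 1 `C#CCSc1nc(Sc2nc(C)c(C)s2)c(C#N)c(-c2cc(OC)c(OC)c(OC)c2)n1`: > 20000 nM (a limit of the assay, not a number)
- Compound 2 `C#CCSc1nc(Sc2nccs2)c(C#N)c(-c2ccc(Br)cc2)n1`: 12100 nM
- Compound 3 `C#CCSc1nc(Sc2nncs2)c(C#N)c(-c2cc(OC)c(OC)c(OC)c2)n1`: 7960 nM

Among the compounds with values here, compound 3 lies within the usual scatter of compound 2, and these are the only two true numbers so far. Compound 4 `C#CCSc1nc(Sc2nc3ccccc3s2)c(C#N)c(-c2cc(OC)c(OC)c(OC)c2)n1` carries 1,3-benzothiazol-2-yl in place of the 1,3,4-thiadiazol-2-yl of compound 3 on a sulfur: 1,3-benzothiazol-2-yl in place of 1,3,4-thiadiazol-2-yl on a sulfur. Within the data shown here, one measured step bears on this site: an at least 2.5-fold lower number from compound 1 to compound 3 (0.40 log units; beyond the scatter). The incoming group resembles the 4,5-dimethyl-1,3-thiazol-2-yl of compound 1, so a move toward weaker inhibition is expected. The expected change is a 2.0-fold higher number from compound 3 to compound 4 (0.30 log units; within the scatter) in this assay. For compound 4 the estimate is 16000 nM, with an expected range from 5000 nM to 45000 nM.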

Compound 4, half-maximal inhibitory concentration: > 20000 nM
Compound 4 gave a limit, no number; the forecaster's own chance of this, stated with the estimate: 35%; at least 1.2-fold (0.09 log units) between middle value and limit.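

In this assay, putting the larger, fused 1,3-benzothiazol-2-yl on this sulfur weakens inhibition, giving an at least 2.5-fold higher number from compound 3 to compound 4 (0.40 log units; beyond the scatter). Two different replacements for the 1,3,4-thiadiazol-2-yl of compound 3 now point the same way, as the step to compound 1 did, so this site responds to the choice of group. Compound 4, like compound 1, sits at a limit rather than a number, so the step between those two cannot be read: the limit of > 20000 nM in this assay, at which 2 of the 4 values shown sit.

The compounds shown leave open whether a group without a ring on this sulfur, such as a longer chain carrying an amine or a carboxylic acid, would give a lower number than compound 3.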